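Methoxy to chloro on the aryl ring: compound 4

The source may report more compounds than this note shows. Statements on the series, on what has been measured and on what is new or still open speak of the compounds shown alone.

Measured so far in a functional assay on C6 cells (Rattus norvegicus) for cytotoxicity, read by MTT assay, with a stated time of 24 h, tested at 12 ug/mL; on this read-out lower numbers stand for a stronger effect and higher numbers for a weaker effect at the one concentration tested:
compound 1 `Cn1nnnc1SCC(=O)N/N=c1/scc(-c2ccccc2)n1-c1ccccc1`, 80.7%
compound 2 `COc1ccc(-c2cs/c(=N/NC(=O)CSc3ncccn3)n2-c2ccccc2)cc1`, 78.4%
compound 3 `COc1ccc(-c2cs/c(=N/NC(=O)CSc3nnc(C)s3)n2-c2ccccc2)cc1`, 53.6%

Compound 2 stands second highest of the three numbers; compound 1 lies within the scatter of it, and compound 3 lies furthest, beyond the scatter. For the measured compounds named here, the one measured step with a single change, a number 24.8 percentage points lower from compound 2 to compound 3 (beyond the scatter), concerns the group on the sulfur and not the aryl ring, so it says nothing directly about the change examined here.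

Compound 4 `O=C(CSc1ncccn1)N/N=c1/scc(-c2ccc(Cl)cc2)n1-c1ccccc1` differs from compound 2 as follows: chloro in place of methoxy on an aromatic carbon. Going by the values given here, no measured pair in this set alters the aryl ring, so there is no step to lean on; the sulfur-side change shows that the series can move, but the aryl-side change is untested. With nothing to point either way, the expectation for compound 4 in this assay is a step of a number 3.4 percentage points lower from compound 2 to compound 4 (within the scatter), that is, no change beyond the scatter, with a range left open for a modest drop. Compound 4 is estimated at 75%, between 55% and 92%.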

Compound 4, a percentage reported as activity, at one concentration (the size of the read-out at that concentration, not a potency): 91.6%
Compound 4: middle estimate off by 16.6 percentage points, on the low side, within the range that was stated.
By their numbers in this assay, from the lowest: compound 3; then compounds 2 and 1 (each within the scatter of the next); then compound 4.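

In this assay the aryl end of the series proves responsive: 4-methoxyphenyl to 4-chlorophenyl gives a number 13.2 percentage points higher from compound 2 to compound 4 (beyond the scatter) and so a weaker effect at the one concentration tested. For the compounds shown here, this position therefore matters as well as the group on the sulfur, although the step runs in the opposite direction to a number 24.8 percentage points lower from compound 2 to compound 3 (beyond the scatter) and the methoxy form is the one of this pair with the stronger effect. No measurement shown bears on the reason for this step.

As far as these compounds go, it remains open whether an amine or a hydroxyl at this place would behave like methoxy or like chloro. Also open, from the compounds shown here alone, is whether the same swap gives a step of similar size with 5-methyl-1,3,4-thiadiazol-2-yl on the sulfur.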